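The compounds below may be only part of what the source reports. "The series", "measured", "known", "first", "only" and "open" are said of these compounds alone.

Working notes on the phenyl chalcogenide sulfates. Compound 3 `O=S(=O)(O)OCCCCCCCCCCCC[Te]c1ccccc1` gives 4960 nM in a functional assay on RAW264.7 cells (Mus musculus) for cytotoxicity, read by MTT assay, with a stated time of 24 h; on this read-out lower numbers stand for stronger inhibition and higher numbers for weaker inhibition; this is the lowest of the two numbers recorded in this assay, with compound 1 `O=S(=O)(O)OCCCCCCCCCC[Te]c1ccccc1` nearest at 5320 nM, the two separated by a 1.1-fold lower number from compound 1 to compound 3 (0.03 log units; within the scatter). Compound 2 `O=S(=O)(O)OCCCCCCCCC[Se]c1ccccc1` returns only the assay limit > 100000 nM in this assay, not a number. Compound 4 `O=S(=O)(O)OCCCCCCCCCCC[Se]c1ccccc1` is the next analogue and differs from compound 3 by a group of 7 heavy atoms (6 carbon, 1 selenium; one six-membered aromatic ring of carbon only) in place of a group of 8 heavy atoms (7 carbon, 1 tellurium; one six-membered aromatic ring of carbon only), on a saturated chain carbon, ten or more bonds along the chain from an oxygen. Within the data shown here, the single measured step, a 1.1-fold lower number from compound 1 to compound 3 (0.03 log units; within the scatter), concerns chain extension alone and lies within the scatter, so it says nothing about exchanging the tellurium-bearing group for the selenium-bearing one. Among the measured compounds shown here, the only selenium-bearing analogue measured, compound 2, sits at the limit (the limit of > 100000 nM in this assay, at which 1 of the 3 values shown sits). Compound 4 is therefore expected to move toward that limit rather than to stay near the number of compound 3. The estimated value for compound 4 is 100000 nM with a range of 30000 nM to 300000 nM, which means an expected step of a 20-fold higher number from compound 3 to compound 4 (1.30 log units; beyond the scatter) toward weaker inhibition, and a real chance that only a limit is reported.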

Compound 4, half-maximal inhibitory concentration: > 100000 nM
Compound 4: a limit, no number; the forecaster's own chance of this, stated with the estimate: 70%; the middle value sits exactly at the limit.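

In this assay, the selenium-bearing group in place of the tellurium-bearing group, on a saturated chain carbon, gives an at least 20-fold higher number from compound 3 to compound 4 (1.30 log units; beyond the scatter). Among these compounds, this is the first step that touches the chalcogen-bearing group, since the earlier step concerned the chain alone; compound 4 returns a limit, not a number, so the step has no upper end. Compound 2 and compound 4 therefore both stand at the limit, the step between them cannot be read, and no selenium-bearing analogue yet gives a number: the limit of > 100000 nM in this assay, at which 2 of the 4 values shown sit.

The compounds shown do not tell whether a sulfur atom in place of the selenium would behave like the selenium or the tellurium analogues. Nor do they show whether a carboxylic acid in place of the sulfooxy group would keep the response of the tellurium-bearing compounds.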